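This account rests on a few compounds, and the source may have more. Where it says the series, first, only, none or still open, it means among the compounds named here.

Among the measured compounds shown here, compound 1, with the structure `CCCCSc1nc(N)nc2c1ncn2/C=C1/CC1(CO)CO`, is the only compound here whose tolerability comes as a number: in an ADME assay on CCRF-HSB-2 cells (Homo sapiens) for cytotoxicity, with a stated time of 7 days (a higher number here means that more compound is tolerated, a lower number that less compound is tolerated), compound 1 gives 89000 nM. Compound 2, with the structure `CCCNc1nc(N)nc2c1ncn2/C=C1/CC1(CO)CO`, differs from it by propylamino in place of butylsulfanyl on an aromatic carbon. In this assay compound 2 gives > 20000 nM, which is a limit of the assay rather than a measured number. The step that the limit leaves unreadable from compound 1 to compound 2 therefore cannot be sized, and the only further fact is the limit of > 20000 nM in this assay, at which 1 of the 2 values shown sits.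

Compound 3, with the structure `CCCOc1nc(N)nc2c1ncn2/C=C1/CC1(CO)CO`, is the compound to be measured. It differs from compound 1 as follows: propoxy in place of butylsulfanyl on an aromatic carbon. For the measured compounds named here, the one measured step, from compound 1 to compound 2, swaps the same butylsulfanyl for a different group and is unreadable, so it gives no direction for the present change. Compound 3 is expected to stay close to compound 1, with a step of a 1.1-fold lower number from compound 1 to compound 3 (0.05 log units; within the scatter) that is within the scatter. The estimate for compound 3 in this assay is 80000 nM, with a range from 30000 nM to 200000 nM.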

Compound 3, half-maximal cytotoxic concentration: > 20000 nM
Compound 3: only a limit was reported; the forecaster's own chance of this, stated with the estimate: 30%; the middle value is on the limit's open side.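

In this assay compound 3 gives only a limit of the assay, so its steps from compound 1 and from compound 2 cannot be read. The compounds shown leave open how much compound is tolerated for compound 2 and compound 3, and so how propoxy, propylamino and butylsulfanyl compare: the limit of > 20000 nM in this assay, at which 2 of the 3 values shown sit.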